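This account rests on a few compounds, and the source may have more. Where it says the series, first, only, none or still open, it means among the compounds named here.

Compound 3 `Cc1cnc(N[C@H]2CC[C@@H](CNC(=O)c3cccc(C(F)(F)F)c3)CC2)nc1N(C)C` is one of three compounds assessed in a functional assay on HEK293 cells for antagonist activity at melanin-concentrating hormone receptor 1 (Homo sapiens), read by FLIPR and calcium flux (a higher number here means a weaker inhibitor, a lower number a stronger inhibitor), and compound 3 gives 26 nM. Compound 1 `Cc1cc(N(C)C)nc(N[C@H]2CC[C@@H](NC(=O)c3ccc(F)cc3)CC2)n1` differs from it in more than one place, and in this assay compound 1 gives 25 nM, a number within the scatter of that of compound 3. Among the compounds with values here, compound 2 `Cc1cnc(N[C@H]2CC[C@@H](CNC(=O)c3ccc(F)c(F)c3)CC2)nc1N(C)C` carries a 3,4-difluorophenyl on the carbonyl carbon, and in this assay compound 2 gives 120 nM; the only single-point step available, a 4.6-fold lower number from compound 2 to compound 3 (0.66 log units; beyond the scatter), shows that swapping the aryl group on that carbonyl can move the number by a modest but real amount.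

Compound 4 `Cc1cnc(N[C@H]2CC[C@@H](CNC(=O)c3cc(Cl)cc(Cl)c3)CC2)nc1N(C)C` is the next member, obtained by the change (3,5-dichlorophenyl in place of 3-(trifluoromethyl)phenyl on a carbonyl carbon). Within the data shown here, the one step that bears on this, from compound 2 to compound 3, concerned the same aryl group, and it favoured the 3-(trifluoromethyl)phenyl over the 3,4-difluorophenyl. Nothing measured here separates a 3,5-dichlorophenyl from a 3-(trifluoromethyl)phenyl, so the expected step, a 1.3-fold lower number from compound 3 to compound 4 (0.11 log units; within the scatter), is taken to lie within the usual scatter. On that basis compound 4 is expected to give about 20 nM in this assay, with a likely range from 6 nM to 65 nM.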

Compound 4, half-maximal inhibitory concentration: 4 nM
Compound 4: middle estimate off by 5.0-fold (0.70 log units), on the high side; the whole stated range lies above it.
By their numbers in this assay, from the lowest: compound 4; then compounds 1 and 3 (each within the scatter of the next); then compound 2.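

In this assay, 3,5-dichlorophenyl in place of 3-(trifluoromethyl)phenyl on the carbonyl carbon gives a 6.5-fold lower number from compound 3 to compound 4 (0.81 log units; beyond the scatter) and so shows that this position still separates two aryl groups that each carry substituents of the kind that had already given a lower number than 3,4-difluorophenyl. The wider step, a 30-fold lower number from compound 2 to compound 4 (1.48 log units; beyond the scatter) for the same position, sets the three aryl groups in a single order with every gap beyond the scatter: 3,5-dichlorophenyl gives the lowest number, 3-(trifluoromethyl)phenyl the next, and 3,4-difluorophenyl the highest. No measurement shown here accounts for that order and the numbers therefore stand only as a ranking of these three groups on this carbonyl carbon.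

The compounds shown leave open whether both chlorines are needed, since a phenyl with one chlorine, a 3,5-dibromophenyl, a 3,5-dimethylphenyl or a 3,5-bis(trifluoromethyl)phenyl does not appear among them. They also leave open whether a dichloropyridine ring in place of the dichlorophenyl would hold the number, and whether the 3,5-dichlorophenyl would give a similar gain on the core of compound 1.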